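Chain shortening at the amide carbonyl of compound 2

The source may hold more compounds than are shown below. What is called first, only, known or untested is meant among the compounds shown, and "the series" means these compounds.

The series shares one core carrying an amide; compound 1 `C/C=C/C(=O)Nc1cccc(Oc2nc(Nc3cccc(OC)c3)nc3c2CSCC3)c1` and compound 2 `CCC/C=C/C(=O)Nc1cccc(Oc2nc(Nc3cccc(OC)c3)nc3c2CSCC3)c1` differ only in the chain on that amide. In a functional assay on HeLa cells (Homo sapiens) for antiproliferative activity, read by MTT assay, with a stated time of 72 h (a higher number here means a weaker inhibitor, a lower number a stronger inhibitor), compound 1 gives 13800 nM, and compound 2 gives 33800 nM. Among the compounds with values here, the one step measured so far, a 2.4-fold higher number from compound 1 to compound 2 (0.39 log units; beyond the scatter), shows that lengthening the chain raised the number beyond the scatter. Within the data shown here, compound 2 stands at the highest of the two numbers in this assay, with compound 1 as its only neighbour.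

Compound 3 `C=C(F)C(=O)Nc1cccc(Oc2nc(Nc3cccc(OC)c3)nc3c2CSCC3)c1` is the next step, (1-fluoroethenyl in place of pent-1-en-1-yl on a carbonyl carbon). Among the measured compounds shown here, only the step from compound 1 to compound 2 bears on this change, and it points the other way: compound 3 carries a chain shorter than either measured compound, so the weakening seen in a 2.4-fold higher number from compound 1 to compound 2 (0.39 log units; beyond the scatter) is expected to be undone and the number of compound 3 is expected to fall at least back toward that of compound 1. For the measured compounds named here, no measured step speaks to the fluorine that enters, so the expected step of a 3.8-fold lower number from compound 2 to compound 3 (0.57 log units; beyond the scatter) for compound 3 carries a wide range. Compound 3 is estimated at 9000 nM in this assay, with a range from 2500 nM to 30000 nM.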

Compound 3, half-maximal inhibitory concentration: 44800 nM
Compound 3: the middle estimate sits 5.0-fold (0.70 log units) below what was measured; the whole stated range lies below it.
By their numbers in this assay, from the lowest: compound 1; then compounds 2 and 3 (each within the scatter of the next).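

In this assay, the exchange of pent-1-en-1-yl for 1-fluoroethenyl on the carbonyl carbon gives a 1.3-fold higher number from compound 2 to compound 3 (0.12 log units; within the scatter) and so leaves the two compounds level, which means a smaller group at this position does not by itself bring the number back to that of compound 1. The exchange of prop-1-en-1-yl for 1-fluoroethenyl gives a 3.2-fold higher number from compound 1 to compound 3 (0.51 log units; beyond the scatter) and leaves compound 1 the strongest of the three, so compound 3 goes against any reading of shorter chain, lower number drawn from the first pair alone. No measurement on hand accounts for this result.

Going by these compounds, whether the fluorine or the shortening of the chain governs the number of compound 3 stays open, as the two differ together in every step to compound 3, and a plain ethenyl group on the same carbonyl carbon would separate them. Also open, on these data alone, is how this assay responds at this position to a saturated propyl chain, which would show what the double bond contributes, or to a chain ending in a dimethylamino group.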